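The source may hold more compounds than are shown below. What is called first, only, known or untested is meant among the compounds shown, and "the series" means these compounds.

Of the compounds shown here, three built on one core have been measured in an assay on cells for agonist activity at ecdysone receptor (Bombyx mori), read by a luciferase reporter, with a stated time of 24 h; on this read-out higher numbers stand for an effect only at larger amounts of compound and lower numbers for an effect already at smaller amounts. Compound 1 `CC(C)(C)N(NC(=O)c1cccc(F)c1)C(=O)c1ccccc1Cl` gives 69.2 nM. Compound 2 `CC(C)(C)N(NC(=O)c1ccc(Cl)cc1)C(=O)c1ccccc1Cl` gives 115 nM. Compound 3 `CC(C)(C)N(NC(=O)c1ccc(I)cc1)C(=O)c1ccccc1Cl` gives 7.59 nM, the lowest of the three numbers, and its steps to the other two are beyond the scatter: a 9.1-fold lower number from compound 1 to compound 3 (0.96 log units; beyond the scatter) and a 15-fold lower number from compound 2 to compound 3 (1.18 log units; beyond the scatter). The step of a 1.7-fold higher number from compound 1 to compound 2 (0.22 log units; within the scatter) is within the scatter.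

Compound 4 `COc1ccc(C(=O)NN(C(=O)c2ccccc2Cl)C(C)(C)C)cc1` differs from compound 3 in one place: methoxy in place of iodo on an aromatic carbon, on an aromatic carbon of a six-membered aromatic ring of carbon only, para to a large group; cut one bond further out, the change reads 4-iodophenyl to 4-methoxyphenyl. The step that bears most directly on this position is a 15-fold lower number from compound 2 to compound 3 (1.18 log units; beyond the scatter), which shows that an exchange of the group at this place can move the number by a large amount. Among the measured compounds shown here, exchanging the iodo for a methoxy has no measured counterpart, so the direction rests on the observation that compound 3 stands apart from compound 1 and compound 2. The expected step is therefore an 11-fold higher number from compound 3 to compound 4 (1.02 log units; beyond the scatter), an increase beyond the scatter. Compound 4 is estimated at 80 nM, with a range from 20 nM to 320 nM.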

Compound 4, half-maximal effective concentration: 51.3 nM
For compound 4 the middle estimate is 1.6-fold (0.19 log units) above the measured one, within the range that was stated.
By their numbers in this assay, from the lowest: compound 3; then compounds 4, 1 and 2 (each within the scatter of the next, the first and the last beyond it).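

In this assay, the low number of compound 3 is not shared by the methoxy group at this place: the change from iodo to methoxy gives a 6.8-fold higher number from compound 3 to compound 4 (0.83 log units; beyond the scatter), and methoxy in place of chloro gives a much smaller shift, a 2.2-fold lower number from compound 2 to compound 4 (0.35 log units; beyond the scatter), which is nonetheless beyond the scatter and shows that a change at this position can matter even when iodo is not involved. The comparison with the 3-fluorophenyl group gives a 1.3-fold lower number from compound 1 to compound 4 (0.13 log units; within the scatter), so among these compounds only the 4-iodophenyl group stands clearly apart from all the others, and the 4-methoxyphenyl and 3-fluorophenyl groups cannot be told apart here. No measurement on hand explains why iodo differs from methoxy or chloro at this position.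

The compounds shown leave open whether the low number belongs to iodo alone or would also appear with a bromo, ethoxy or trifluoromethyl group at this place. They also leave open how an amine or a carboxylic acid at the same position would read, and whether a longer chain in place of methoxy would move the number in either direction.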